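The source may hold more compounds than are shown below. What is called first, only, known or untested is meant among the compounds shown, and "the series" means these compounds.

Measured compounds and their maximal responses:

Compound 1 `Cc1cnc(N2CCC(c3coc4c(N5CCc6cc(S(C)(=O)=O)ccc65)ncnc34)CC2)nc1` gives 159% in a functional assay on cells for agonist activity at Glucose-dependent insulinotropic receptor (Homo sapiens), read by a luciferase reporter, with a stated time of 4 h; on this read-out lower numbers stand for smaller maximal responses and higher numbers for larger maximal responses.
Compound 2 `CC(C)(C)OC(=O)N1CCC(c2coc3c(N4CCCc5cc(S(C)(=O)=O)ccc54)ncnc23)CC1` gives 1% in this assay.
Compound 3 `CCc1cnc(N2CCC(c3coc4c(N5CCc6cc(S(C)(=O)=O)ccc65)ncnc34)CC2)nc1` gives 154% in this assay.

Compound 3 stands second highest of the three numbers. Its nearest neighbour is compound 1, and the step of a number 5 percentage points lower from compound 1 to compound 3 (within the scatter) lies within the scatter, so the two maximal responses cannot be told apart. Compound 2 is the furthest away: its value sits far beneath that of compound 3, well beyond the scatter.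

The compound not yet measured is compound 4 `CS(=O)(=O)c1ccc2c(c1)CCN2c1ncnc2c(C3CCN(c4ncccn4)CC3)coc12`. Relative to compound 3 the change is hydrogen in place of ethyl on an aromatic carbon. Going by the values given here, the one measured step that bears on this place is the one from compound 1 to compound 3, where methyl in place of hydrogen on the saturated chain carbon bound to the same aromatic carbon moved the maximal response by a number 5 percentage points lower from compound 1 to compound 3 (within the scatter), within the scatter. Among the compounds with values here, removing the whole ethyl from the six-membered aromatic ring with 2 nitrogen goes one step further in the same direction, and no measured step suggests a change of real size at this position. The expected step of a number 1 percentage points higher from compound 3 to compound 4 (within the scatter) is therefore none beyond the scatter.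

Compound 4 is estimated to give 155% in this assay, with a range from 125% to 185%.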

Compound 4, largest response reached (Emax), in percent of the reference or control that the assay uses: 196%
The estimate for compound 4 lay 41 percentage points below the measured number; measured number outside the range, above it.
By their numbers in this assay, from the lowest: compound 2; then compounds 3 and 1 (each within the scatter of the next); then compound 4.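

In this assay, this position proves sensitive to the change from an alkyl group to hydrogen: going from 5-ethylpyrimidin-2-yl to pyrimidin-2-yl gives a number 42 percentage points higher from compound 3 to compound 4 (beyond the scatter), and losing methyl at the same aromatic carbon gives a number 37 percentage points higher from compound 1 to compound 4 (beyond the scatter). The earlier comparison of methyl with ethyl, a number 5 percentage points lower from compound 1 to compound 3 (within the scatter), could not show this, as it stayed within the scatter; the step beyond the scatter appears only when hydrogen replaces either alkyl group, so among the three substituents shown, the clear divide lies between hydrogen and alkyl rather than between the two alkyl groups. Nothing on hand accounts for this difference.

On these data alone, it remains open whether a fluorine, a methoxy group or an amine on this aromatic carbon would keep the maximal response of compound 4 or bring it back towards those of compound 1 and compound 3. As far as these compounds go, how potency at the receptor moves with the same change also stays open, as only maximal responses are given for these compounds.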